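The source may hold more compounds than are shown below. What is called first, only, known or untested is meant among the compounds shown, and "the series" means these compounds.

Series notes. Compound 1 `O=C(O)Cc1sc(C(c2ccccc2)c2ccc(F)c(F)c2)nc1-c1ccc(F)cc1` gives 10 nM in an in vitro assay on HEK385-7 cells for displacement of a labelled ligand from prostaglandin D2 receptor 2 (Homo sapiens); a lower number here means a stronger inhibitor, a higher number a weaker inhibitor. For the measured compounds named here, compound 2 `O=C(O)Cc1sc(C(c2ccc(F)cc2)c2ccc(F)cc2)nc1-c1ccco1` gives 18 nM in this assay, the higher of the two numbers so far, though compound 1 lies within the scatter of it, so no ordering is drawn. Compound 3 `O=C(O)Cc1sc(C(c2ccc(F)cc2)c2ccc(F)cc2)nc1-c1ccnc(N2CCC2)c1` is not yet measured; it differs from compound 2 by 2-(azetidin-1-yl)pyridin-4-yl in place of furan-2-yl on an aromatic carbon. Going by the values given here, no measured pair in the set carries this change, so direction is unknown; a step no larger than the scatter is expected a 1.3-fold lower number from compound 2 to compound 3 (0.11 log units; within the scatter). Compound 3 is estimated at 14 nM, with a range from 3 nM to 60 nM.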

Compound 3, half-maximal inhibitory concentration: 660 nM
Beside the measured number, compound 3's estimate is 47-fold (1.67 log units) below it; measured number outside the range, above it.
By their numbers in this assay, from the lowest: compounds 1 and 2 (each within the scatter of the next); then compound 3.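

This aromatic carbon, next to the ring nitrogen, does not tolerate every aromatic group: 2-(azetidin-1-yl)pyridin-4-yl in place of furan-2-yl gives a 37-fold higher number from compound 2 to compound 3 (1.56 log units; beyond the scatter) in this assay. For the compounds shown here, this is the first single-place step, and it replaces a five-membered aromatic ring with a six-membered aromatic ring carrying a four-membered non-aromatic ring.

The compounds shown do not separate the contribution of the azetidine from that of the pyridine, which an unsubstituted pyridin-4-yl or a 2-(dimethylamino)pyridin-4-yl at this carbon could address. No available evidence explains the size of this step.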